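Cycloheptyloxy for diethylamino on the coumarin-ester core

The source may hold more compounds than are shown below. What is called first, only, known or untested is meant among the compounds shown, and "the series" means these compounds.

Compound 3 `CCOC(=O)c1cc2ccc(N(CC)CC)cc2oc1=O` gives 45500 nM in an in vitro assay on BTI-TN-5B1-4 cells for inhibition of Amine oxidase [flavin-containing] B (Homo sapiens), read by fluorescence, with a stated time of 15 min (a higher number here means a weaker inhibitor, a lower number a stronger inhibitor), the highest of the three numbers; the gap to compound 2 `CCN(CC)c1ccc2cc(C(=O)c3ccccc3)c(=O)oc2c1` at 23800 nM is within the scatter, the gap to compound 1 `O=C(c1ccccc1)c1cc2cc(O)ccc2oc1=O` at 18000 nM is beyond it. Among the measured compounds shown here, the one measured step, a 1.9-fold higher number from compound 2 to compound 3 (0.28 log units; within the scatter), swaps the group on the carbonyl carbon and leaves the aromatic substituent untouched. Compound 4 `CCOC(=O)c1cc2ccc(OC3CCCCCC3)cc2oc1=O` changes that substituent instead: cycloheptyloxy in place of diethylamino on an aromatic carbon. For the measured compounds named here, no measured step bears on this exchange, so no direction can be read from the data. Expected for compound 4 is a modest movement, a 1.0-fold lower number from compound 3 to compound 4 (0.00 log units; within the scatter), uncertain in sign. The estimate for compound 4 is 45000 nM, with a range from 15000 nM to 130000 nM.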

Compound 4, half-maximal inhibitory concentration: 21.5 nM
Compound 4: the middle estimate sits 2100-fold (3.32 log units) above what was measured, outside the stated range (below it).
By their numbers in this assay, from the lowest: compound 4; then compounds 1, 2 and 3 (each within the scatter of the next, the first and the last beyond it).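

In this assay the substituent on the aromatic carbon counts for far more than the group on the carbonyl carbon: cycloheptyloxy in place of diethylamino gives a 2100-fold lower number from compound 3 to compound 4 (3.33 log units; beyond the scatter), while the carbonyl exchange stays within the scatter. This position is therefore highly sensitive to the group it carries, at least on the ester core. Nothing available explains the size of this step.

The exchange alters both the linking atom and the ring, leaving the share of each unresolved. Cycloheptylamino or methoxy here would separate them.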